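Aryl swap on the shared core: paw edema notes

The compounds below may be only part of what the source reports. "The series", "measured", "known", "first", "only" and "open" are said of these compounds alone.

Measured so far:
compound 1 `O=C(CO[N+](=O)[O-])NNC(=O)c1ccc(-n2[nH]c(=O)cc2-c2ccc([N+](=O)[O-])cc2)cc1`: 27.1%
compound 2 `O=C(CO[N+](=O)[O-])NNC(=O)c1ccc(-n2[nH]c(=O)cc2-c2ccccc2O)cc1`: 19.3%

In a functional assay on the whole organism (strain Wistar) for inhibition, with Rattus norvegicus as the target, read by paw edema, with stated times of 2 h and 1 h, at a dose of 6 mg/kg by the oral route (on this read-out lower numbers stand for less inhibition and higher numbers for more inhibition at the one dose given (going by the name of the read-out)), compound 1 gives 27.1% and compound 2 gives 19.3%. For the measured compounds named here, compound 2 stands lowest of the two numbers, with compound 1 nearest; the only measured step, a number 7.8 percentage points lower from compound 1 to compound 2 (within the scatter), is a swap of the aryl group on the same aromatic carbon of the core and lies within the scatter, so the two values cannot be ordered.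

Compound 3 `O=C(CO[N+](=O)[O-])NNC(=O)c1ccc(-n2[nH]c(=O)cc2-c2ccc(Cl)cc2)cc1` is not yet measured. It differs from compound 2 as 4-chlorophenyl in place of 2-hydroxyphenyl on an aromatic carbon. Going by the values given here, the step from compound 1 to compound 2 is the one measured step that bears on this change, since it alters the same group at the same place, and it was within the scatter. On that basis the step is expected to be a number 2.7 percentage points higher from compound 2 to compound 3 (within the scatter), with no movement beyond the scatter in either direction. Compound 3 is therefore estimated at 22%, between 10% and 36%.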

Compound 3, a percentage reported as inhibition, in the whole organism at one dose (the size of the read-out at that dose, not a potency): 11.5%
Compound 3: middle estimate off by 10.5 percentage points, on the high side; low and high end bracket the measured number.
By their numbers in this assay, from the lowest: compounds 3, 2 and 1 (each within the scatter of the next, the first and the last beyond it).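

In this assay, for the compounds shown here, chloro in place of nitro on the aromatic ring at this position gives a number 15.6 percentage points lower from compound 1 to compound 3 (beyond the scatter), the only step beyond the scatter, so a change on this aryl group can move the read-out, if modestly. The swap of 2-hydroxyphenyl for 4-chlorophenyl gives a number 7.8 percentage points lower from compound 2 to compound 3 (within the scatter), so that change alone still cannot be ordered, and compound 2 cannot be separated from either neighbour. Nothing measured here accounts for the step from nitro to chloro.

The compounds shown leave open whether an amine or a carboxylic acid on the same phenyl ring would read closer to compound 1 or to compound 3. They also leave open whether hydroxy in the 4-position of that ring would read differently from 2-hydroxyphenyl.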